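The source may report more compounds than this note shows. Statements on the series, on what has been measured and on what is new or still open speak of the compounds shown alone.

Two compounds share one core and differ only in the group attached to the amide-type nitrogen. In an assay on CHO cells for displacement of a labelled ligand from transient receptor potential cation channel subfamily V member 1 (Homo sapiens), read by scintillation counting, with a stated time of 60 min (a higher number here means a weaker inhibitor, a lower number a stronger inhibitor), compound 1 `CN(C)C1(Cc2ccccc2)CCN(c2cc(C(F)(F)F)ccc2CNC(=O)Nc2ccc(CNS(N)(=O)=O)c(F)c2)CC1` gives 15.3 nM, while compound 2 `CN(C)C1(Cc2ccccc2)CCN(c2cc(C(F)(F)F)ccc2CNC(=O)Nc2cccc3ccc(O)cc23)CC1` gives 0.46 nM, the lower of the two numbers and a gap beyond the scatter. Compound 3 `CN(C)C1(Cc2ccccc2)CCN(c2cc(C(F)(F)F)ccc2CNC(=O)Nc2ccc3ccncc3c2)CC1` carries isoquinolin-7-yl in place of 7-hydroxynaphthalen-1-yl on an amide-type nitrogen, and with the leaving group one hydrogen-bond donor goes. Among the compounds with values here, no measured pair shows this exchange, so the step is an expectation only: a modest weakening is estimated, a 6.5-fold higher number from compound 2 to compound 3 (0.81 log units; beyond the scatter). Compound 3 is expected to give 3 nM in this assay, somewhere between 0.8 nM and 12 nM.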

Compound 3, inhibition constant: 7.33 nM
Compound 3: the middle estimate sits 2.4-fold (0.39 log units) below what was measured; the range from low to high includes it.
By their numbers in this assay, from the lowest: compound 2; then compound 3; then compound 1.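

In this assay, replacing 7-hydroxynaphthalen-1-yl with isoquinolin-7-yl on this amide-type nitrogen gives a 16-fold higher number from compound 2 to compound 3 (1.20 log units; beyond the scatter), so binding is sensitive to this exchange. The step removes a hydrogen-bond donor and also brings a ring nitrogen, so this one pair cannot separate the two changes. No measurement shown here explains the loss. Still open, from the compounds shown here alone, is how much of the step belongs to the hydroxyl itself. A methoxy group in its place on the naphthalene, or a hydroxyl added to the isoquinoline, would help to separate these contributions.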